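This account rests on a few compounds, and the source may have more. Where it says the series, first, only, none or still open, it means among the compounds named here.

Compound 1 `CCCCNC(=O)OC/C=C(\C)C1=CC(=O)C(C)(C)O1`: 5.3 ug/mL
Compound 2 `C/C(=C\COC(=O)NC(C)C)C1=CC(=O)C(C)(C)O1`: 6.6 ug/mL
Compound 3 `C/C(=C\COC(=O)NC1CCCCC1)C1=CC(=O)C(C)(C)O1`: 3.4 ug/mL

These three compounds were tested in a functional assay on MOLT-4F cells (Homo sapiens) for inhibition; on this read-out higher numbers stand for weaker inhibition and lower numbers for stronger inhibition. Compound 1 holds no clear rank among them, with a 1.2-fold higher number from compound 1 to compound 2 (0.10 log units; within the scatter) and a 1.6-fold lower number from compound 1 to compound 3 (0.19 log units; within the scatter). Compound 4 `C/C(=C\COC(=O)NCc1ccccc1)C1=CC(=O)C(C)(C)O1` has not yet been measured. It differs from compound 1 as follows: phenyl in place of propyl on a saturated chain carbon bound to an amide-type nitrogen. In words, this is phenyl in place of propyl on a saturated chain carbon bound to an amide-type nitrogen, or butyl to benzyl when cut one bond further out.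

Among the measured compounds shown here, all the measured steps change the group on that same amide-type nitrogen, and the third is a 1.9-fold lower number from compound 2 to compound 3 (0.29 log units; within the scatter). Butyl, isopropyl and cyclohexyl therefore leave this assay essentially unmoved. None of the three measured compounds carries an aromatic ring, so the data do not test this change directly, and the expectation remains loose. The expected result is no step beyond the scatter, and the estimated step is a 1.2-fold lower number from compound 1 to compound 4 (0.07 log units; within the scatter). For compound 4 the estimated value is 4.5 ug/mL, with an expected range from 2.2 ug/mL to 9 ug/mL.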

Compound 4, half-maximal inhibitory concentration: 6 ug/mL
Beside the measured number, compound 4's estimate is 1.3-fold (0.12 log units) below it, within the range that was stated.
By their numbers in this assay, from the lowest: compounds 3, 1, 4 and 2 (each within the scatter of the next).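

In this assay, among the compounds shown here, an aromatic ring on this amide-type nitrogen is tested for the first time, and butyl to benzyl gives a 1.1-fold higher number from compound 1 to compound 4 (0.05 log units; within the scatter) as its whole effect. Benzyl in place of cyclohexyl gives a 1.8-fold higher number from compound 3 to compound 4 (0.25 log units; within the scatter) and benzyl in place of isopropyl gives a 1.1-fold lower number from compound 2 to compound 4 (0.04 log units; within the scatter) so the four groups on this nitrogen, aromatic or saturated, cannot be told apart in this read-out. No evidence is available that would explain this flat response.

The compounds shown leave open whether an amine, a carboxylic acid or a longer chain such as octyl on this nitrogen would move the number beyond the scatter. All four differ only at this nitrogen, so they also leave open how changes elsewhere on the shared core would read.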